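The compounds below may be only part of what the source reports. "The series", "measured", "known", "first", "only" and "open" are said of these compounds alone.

Compound 1 `COc1ccc(NC(=O)COc2cc(C)nc3ccc(OC)cc23)cc1` is the reference point. In an ADME assay on HepG2 cells (Homo sapiens) for cytotoxicity, read by trypan blue exclusion, with a stated time of 48 h, in the presence of a further agent that is not named here (a lower number here means that less compound is tolerated, a higher number that more compound is tolerated), compound 1 gives > 142000 nM, a limit of the assay. Compound 2 `COc1ccc(NC(=O)COc2cc(C)nc3ccc(OC)cc23)c(OC)c1` in this assay gives > 131000 nM, also a limit. Compound 3 `COc1ccc2nc(C)cc(OCC(=O)Nc3ccc(-c4ccccc4)cc3)c2c1` in this assay gives > 126000 nM, again a limit. The steps a step that the two limits leave unreadable from compound 1 to compound 2 and a step that the two limits leave unreadable from compound 1 to compound 3 therefore cannot be sized, as all three values sit at limits (the limit of > 126000 nM in this assay, at which 1 of the 3 values shown sits, (the limit of > 131000 nM in this assay, at which 1 of the 3 values shown sits), (the limit of > 142000 nM in this assay, at which 1 of the 3 values shown sits)). Compound 4 `COCCNC(=O)COc1cc(C)nc2ccc(OC)cc12` differs from compound 1 by 2-methoxyethyl in place of 4-methoxyphenyl on an amide-type nitrogen. Within the data shown here, no measured step bears directly on this change, and no step from compound 1 has a readable size. Compound 4 is expected to sit at a limit as well, with no step beyond the scatter expected in this assay, the expected step being a step that the limit leaves unreadable from compound 1 to compound 4. The estimate for compound 4 is 150000 nM, in the range 60000 nM to 400000 nM.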

Compound 4, half-maximal cytotoxic concentration: > 164000 nM
Compound 4: only a limit was reported; the forecaster's own chance of this, stated with the estimate: 80%; middle value at least 1.0-fold (0.03 log units) away from the limit.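

In this assay compound 4 gives > 164000 nM, a limit of the assay. Compound 1 and compound 4 both stand at limits, so the step between them cannot be read. The compounds shown leave open the concentration at which compound 1, compound 2, compound 3 or compound 4 reaches half-maximal cytotoxicity.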